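Series notes: aryl imine variation on the shared core

The source may report more compounds than this note shows. Statements on the series, on what has been measured and on what is new or still open speak of the compounds shown alone.

Compound 1 `O=C(NNc1ccnc2cc(Cl)ccc12)c1ccccc1/N=C/c1ccc(Cl)cc1` is the reference point. In a physicochemical assay for lipophilicity, measured as octanol-water partition (a lower number here means a more polar compound, a higher number a more lipophilic compound), compound 1 gives 5.62, the highest of the three numbers recorded so far. Compound 2 `COc1ccc(/C=N/c2ccccc2C(=O)NNc2ccnc3cc(Cl)ccc23)cc1OC` gives 4.97 and compound 3 `O=C(NNc1ccnc2cc(Cl)ccc12)c1ccccc1/N=C/c1ccc([N+](=O)[O-])cc1` gives 4.58; both steps from compound 1 lie beyond the scatter, a number 0.65 log units lower from compound 1 to compound 2 (beyond the scatter) and a number 1.04 log units lower from compound 1 to compound 3 (beyond the scatter), and between the two a number 0.39 log units lower from compound 2 to compound 3 (beyond the scatter).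

Compound 4 `CN(C)c1ccc(/C=N/c2ccccc2C(=O)NNc2ccnc3cc(Cl)ccc23)cc1` is not yet measured. Its difference from compound 1 is dimethylamino in place of chloro on an aromatic carbon. Every measured step exchanges the group on the same aromatic carbon of the 4-chlorophenyl ring, and each exchange has lowered this assay, modestly for 3,4-dimethoxyphenyl and by a large amount for nitro. A dimethylamino group in that position is expected to behave in the same direction, with a step of modest size, beyond the scatter but short of the drop seen with nitro.

The expectation for compound 4 is therefore 5.1, in the range 4.7 to 5.5, which corresponds to an expected step of a number 0.52 log units lower from compound 1 to compound 4 (beyond the scatter).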

Compound 4, partition coefficient: 5.03
Compound 4: the middle estimate sits 0.07 log units above what was measured; the measured number falls inside the stated range.
By their numbers in this assay, from the lowest: compound 3; then compounds 2 and 4 (each within the scatter of the next); then compound 1.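

In this assay the exchange of chloro for dimethylamino gives a number 0.59 log units lower from compound 1 to compound 4 (beyond the scatter) and so adds a third group that lowers the number relative to compound 1, with no compound shown going against this. The size of the step depends on the group that enters and not merely on the presence of nitrogen, as two nitrogen-bearing groups on this aromatic carbon differ by a number 0.45 log units higher from compound 3 to compound 4 (beyond the scatter) in this comparison. By contrast, 4-(dimethylamino)phenyl and 3,4-dimethoxyphenyl cannot be told apart, with a number 0.06 log units higher from compound 2 to compound 4 (within the scatter) as the printed step. No measurement bears on why these groups fall where they do.

Still open, going by these compounds, is where a methyl group, a longer alkyl chain or a carboxylic acid on this aromatic carbon would stand relative to compound 1. Also open, on these data alone, is whether the exchange of chloro for dimethylamino gives a step of similar size on a different core.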